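The source may hold more compounds than are shown below. What is called first, only, known or untested is meant among the compounds shown, and "the series" means these compounds.

Compound 3 `COC(=O)C1=C(C)N=C(C)/C(=C(\O)OC)C1c1ccc(C#N)cc1` carries a 4-cyanophenyl group on the shared core. In a functional assay (muscle tissue) with Cavia porcellus as the target (on this read-out lower numbers stand for an effect already at smaller amounts and higher numbers for an effect only at larger amounts of compound), compound 3 gives 3470 nM. Among the three measured compounds this is the second highest number: compound 1 `COC(=O)C1=C(C)N=C(C)/C(=C(\O)OC)C1c1ccc(I)cc1`, which carries 4-iodophenyl instead, gives 22900 nM in this assay, and compound 2 `COC(=O)C1=C(C)N=C(C)/C(=C(\O)OC)C1c1ccccc1C`, which carries 2-methylphenyl, gives 6.03 nM. The step of a 6.6-fold lower number from compound 1 to compound 3 (0.82 log units; beyond the scatter) is modest, whereas a 580-fold higher number from compound 2 to compound 3 (2.76 log units; beyond the scatter) is large.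

Compound 4 `COC(=O)C1=C(C)N=C(C)/C(=C(\O)OC)C1c1ccc(Br)cc1` differs from compound 3 by a single change: bromo in place of cyano on an aromatic carbon. Within the data shown here, the only measured step that touches this spot is a 6.6-fold lower number from compound 1 to compound 3 (0.82 log units; beyond the scatter), where the exchange of iodo for cyano gave a lower number. Exchanging cyano for bromo moves back toward iodo, the group found in compound 1, so a modest rise is expected, most likely landing between the value of compound 3 and that of compound 1. The step of a 3800-fold lower number from compound 1 to compound 2 (3.58 log units; beyond the scatter) does not bear on this, since it replaces the whole group on the saturated ring carbon. The expected step is a 2.9-fold higher number from compound 3 to compound 4 (0.46 log units; beyond the scatter), and compound 4 is estimated at 10000 nM in this assay, with a range from 3000 nM to 35000 nM.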

Compound 4, half-maximal effective concentration: 540 nM
For compound 4 the middle estimate is 19-fold (1.27 log units) above the measured one; the measured number lies below the stated range.
By their numbers in this assay, from the lowest: compound 2; then compound 4; then compound 3; then compound 1.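

Swapping one halogen for another on this aromatic carbon turns out to be far from a minor edit in this assay: a 42-fold lower number from compound 1 to compound 4 (1.63 log units; beyond the scatter), although bromo and iodo are each a single atom at the same spot. The two halogens therefore do not land together, and the nitrile of compound 3 falls between them, with a 6.4-fold lower number from compound 3 to compound 4 (0.81 log units; beyond the scatter) once its cyano group gives way to bromo. Even this better of the two halogen compounds does not match the 2-methylphenyl group on the saturated ring carbon, as a 90-fold higher number from compound 2 to compound 4 (1.95 log units; beyond the scatter) still shows a large gap.

No measurement at hand explains why bromo and iodo lie so far apart, or why cyano falls between them. As far as these compounds go, it remains open where a chloro, a methoxy or an amino group on this same aromatic carbon would fall relative to bromo and iodo, and whether the low number of compound 2 comes from its methyl group itself or from where that group sits on the ring.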